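The source may report more compounds than this note shows. Statements on the series, on what has been measured and on what is new or still open speak of the compounds shown alone.

Compound 1 `CCO/C(O)=C1\C(COCCn2c(C)nc(C)c2C)=NC(C)=C(C(=O)OC)C1c1ccccc1Cl` is drawn with no configuration at its saturated ring carbon. In a functional assay for inhibition of platelet-activating factor receptor (Homo sapiens) (a lower number here means a stronger inhibitor, a higher number a weaker inhibitor), compound 1 gives 21 nM, the second highest of three numbers. Compound 2 `CCO/C(O)=C1\C(COCCn2c(C)nc(C)c2C)=NC(C)=C(C(=O)OC)[C@H]1c1ccccc1Cl` gives 15 nM and compound 3 `CCO/C(O)=C1\C(COCCn2c(C)nc(C)c2C)=NC(C)=C(C(=O)OC)[C@@H]1c1ccccc1Cl` gives 183 nM. Those two differ only in configuration (the fact that compounds 2 and 3 differ only in the configuration as drawn), and the step of a 12-fold higher number from compound 2 to compound 3 (1.09 log units; beyond the scatter) is large, whereas a 1.4-fold lower number from compound 1 to compound 2 (0.15 log units; within the scatter) and an 8.7-fold higher number from compound 1 to compound 3 (0.94 log units; beyond the scatter). Compound 4 `CCO/C(O)=C1\C(COCCn2c(C)nc(C)c2C)=NC(C)=C(C(=O)Nc2ccccc2)C1c1ccccc1Cl` carries a change of another kind: anilino in place of methoxy on a carbonyl carbon. Among the measured compounds shown here, none of the measured steps touches the carbonyl; all concern the ring stereocentre, so they give no guide to the size or direction of this move in this assay. The step is therefore expected to be small, a 1.9-fold higher number from compound 1 to compound 4 (0.28 log units; within the scatter), with wide uncertainty. Compound 4 is expected at 40 nM, within a range from 8 nM to 300 nM.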

Compound 4, half-maximal inhibitory concentration: 17 nM
Estimate against measurement, compound 4: 2.4-fold (0.37 log units) above; measured number inside the range.
By their numbers in this assay, from the lowest: compounds 2, 4 and 1 (each within the scatter of the next); then compound 3.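

In this assay, the change to anilino on this carbonyl carbon is a 1.2-fold lower number from compound 1 to compound 4 (0.09 log units; within the scatter), so the number stays within the scatter. The earlier compounds shown here varied only the ring stereocentre, whereas this result shows that the position tolerates anilino, with its six-membered aromatic ring and hydrogen-bond donor, in place of methoxy.

Still open, on these data alone, is how a methylamino group or a hydroxyl, which would make a carboxylic acid, would fare on this carbonyl carbon, and which configuration at the ring stereocentre of compound 4 matters. Nothing shown here explains why the number holds through this change.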